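Cyclopentyl for Cyclobutyl on the Aminopurine Core

A few compounds are considered here, and "the series" means these few. Any claim that something is new, unique, unknown or untested is made for them only; others in the source may bear on it.

Measured so far:
compound 1 `Cn1c(-c2ccc(C(=O)O)cc2)nc2c(NC3CCCC3)ncnc21`: 54000 nM
compound 2 `Cn1c(-c2ccccc2)nc2c(NC3CCC3)ncnc21`: 3.2 nM

In an assay on CHO cells for displacement of a labelled ligand from adenosine receptor A1 (Homo sapiens), read by scintillation counting, with a stated time of 3 h (on this read-out higher numbers stand for weaker inhibition and lower numbers for stronger inhibition), compound 2 gives 3.2 nM, the lowest of the two numbers measured; compound 1 gives 54000 nM, a gap well beyond the scatter. Compound 3 `Cn1c(-c2ccccc2)nc2c(NC3CCCC3)ncnc21` differs from compound 2 by a single change: cyclopentyl in place of cyclobutyl on a nitrogen on an aromatic ring. For the measured compounds named here, no measured pair isolates this change, so the step is expected to be small, within the scatter or slightly towards a lower number: a 1.1-fold lower number from compound 2 to compound 3 (0.03 log units; within the scatter). Compound 3 is therefore estimated to give 3 nM, with a range from 0.8 nM to 12 nM.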

Compound 3, inhibition constant: 2.8 nM
Estimate against measurement, compound 3: 1.1-fold (0.03 log units) above; the measured number falls inside the stated range.
By their numbers in this assay, from the lowest: compounds 3 and 2 (each within the scatter of the next); then compound 1.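

In this assay cyclopentyl in place of cyclobutyl gives a 1.1-fold lower number from compound 2 to compound 3 (0.06 log units; within the scatter) and so the two rings on this nitrogen cannot be told apart here. Hydrogen in place of carboxy on an aromatic carbon gives a 19000-fold lower number from compound 1 to compound 3 (4.29 log units; beyond the scatter) and so the large gap seen earlier goes with the carboxy group and not with the ring on the nitrogen. Nothing measured here explains either step. Still open, as far as these compounds go, is whether a cyclohexyl ring or an open chain such as propyl on this nitrogen keeps the number in the same range. Also open, from the compounds shown here alone, is whether an amide or a hydroxy group in place of carboxy tracks with hydrogen or with carboxy.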